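From compound 3 to compound 4

The source may hold more compounds than are shown below. What is called first, only, known or untested is meant among the compounds shown, and "the series" means these compounds.

Compound 1 `Cc1ccc(C)c(-c2nc(CN3CCC(C(=O)NCCCN4C[C@H](C)C[C@H](C)C4)CC3)c(C)o2)c1`: 56.1 ug/mL
Compound 2 `Cc1oc(-c2c(Cl)cccc2C(F)(F)F)nc1CN1CCC(C(=O)NCCCN2C[C@H](C)C[C@H](C)C2)CC1`: 65.1 ug/mL
Compound 3 `Cc1cccc(-c2nc(CN3CCC(C(=O)NCCCN4C[C@H](C)C[C@H](C)C4)CC3)c(C)o2)c1`: > 69 ug/mL (a limit, not a number)

In a physicochemical assay for solubility, in phosphate buffer, measured as kinetic solubility, at pH 7.4 (on this read-out higher numbers stand for higher solubility and lower numbers for lower solubility), compound 3 gives > 69 ug/mL, which is a limit of the assay. Compound 3 stands at the limit of > 69 ug/mL in this assay, at which 1 of the 3 values shown sits.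

Compound 4 `COc1cccc(Br)c1-c1nc(CN2CCC(C(=O)NCCCN3C[C@H](C)C[C@H](C)C3)CC2)c(C)o1` differs from compound 3 in a single group: 2-bromo-6-methoxyphenyl in place of 3-methylphenyl on an aromatic carbon.

Among the measured compounds shown here, three measured steps bear on this change. Placing 2-chloro-6-(trifluoromethyl)phenyl in place of 2,5-dimethylphenyl gave a 1.2-fold higher number from compound 1 to compound 2 (0.06 log units; within the scatter). Replacing 2,5-dimethylphenyl with 3-methylphenyl gave an at least 1.2-fold higher number from compound 1 to compound 3 (0.08 log units; that floor lies within the scatter). The step closest to the present one, since it also starts from or ends at 3-methylphenyl and involves a group named in the same pattern as 2-bromo-6-methoxyphenyl, gave an at least 1.0-fold higher number from compound 2 to compound 3 (0.02 log units; that floor lies within the scatter).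

None of these steps leaves the scatter, so no step beyond the scatter is expected in this assay, and the estimate is an at least 1.1-fold lower number from compound 3 to compound 4 (0.06 log units; that floor lies within the scatter). Compound 4 is expected at 60 ug/mL, with an estimated range of 30 ug/mL to 85 ug/mL.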

Compound 4, solubility: > 83 ug/mL
Compound 4 was reported as a limit; the forecaster's own chance of this, stated with the estimate: 35%; middle value at least 1.3-fold (0.14 log units) from the limit.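

In this assay, compound 4 is reported as a limit, not a number: the limit of > 83 ug/mL in this assay, at which 1 of the 4 values shown sits. At this place on the ring, 2-bromo-6-methoxyphenyl, the first group shown here to bring an oxygen, a bromine and a hydrogen-bond acceptor, gives an at least 1.2-fold higher number from compound 2 to compound 4 (0.10 log units; that floor lies within the scatter) and an at least 1.4-fold higher number from compound 1 to compound 4 (0.17 log units; that floor lies within the scatter), so these new groups come with no measured loss against either compound. The step from compound 3 to compound 4 cannot be read, as both ends are limits.

On these data alone, how far compound 3 and compound 4 actually lie from each other therefore stays open. Also open, as far as these compounds go, is what the same read-out would give for a phenyl carrying an amine or a carboxylic acid, or for a pyridine in place of the phenyl.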